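Compound 4 Trades the Methoxyphenyl Amide Arm for Isopropyl

The source may hold more compounds than are shown below. What is called first, only, known or untested is meant among the compounds shown, and "the series" means these compounds.

Compound 2 `COc1ccc(CNC(=O)c2c(N)sc(-c3ccc(Cl)cc3)c2-c2ccc(Cl)cc2)cc1` and compound 1 `CN1CCN(C(=O)c2c(N)sc(-c3ccc(Cl)cc3)c2-c2ccc(Cl)cc2)CC1` share one core and differ only in the group on the carbonyl carbon. For the measured compounds named here, in a functional assay on A549 cells (Homo sapiens) for inhibition, read by sulforhodamine B assay, with a stated time of 72 h (on this read-out higher numbers stand for weaker inhibition and lower numbers for stronger inhibition), compound 1 gives 590 nM, while compound 2 gives 18200 nM, the higher of the two numbers recorded; the single step between them, a 31-fold higher number from compound 1 to compound 2 (1.49 log units; beyond the scatter), is the only measured change in this set. A third congener, compound 3 `CCN(CC)CCNC(=O)Nc1sc(-c2ccc(Cl)cc2)c(-c2ccc(Cl)cc2)c1C(=O)NC1CC1`, carries a different substitution pattern, and in this assay compound 3 gives "not determined" (no result reported), so no number is available for it.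

Compound 4 `CC(C)CNC(=O)c1c(N)sc(-c2ccc(Cl)cc2)c1-c1ccc(Cl)cc1` is reached from compound 2 by isopropyl in place of 4-methoxyphenyl on a saturated chain carbon bound to an amide-type nitrogen. Going by the values given here, no measured step covers this exchange: the one known step concerns the 4-methylpiperazin-1-yl group rather than the amide substituent seen here, so it gives no direct guide. With only a weak handle, the author expects compound 4 to remain near compound 2 in this assay, with a modest lower number possible, so that a 1.5-fold lower number from compound 2 to compound 4 (0.18 log units; within the scatter) is the expected change. The estimate for compound 4 is 12000 nM, ranging from 3000 nM to 45000 nM.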

Compound 4, half-maximal inhibitory concentration: 21000 nM
Estimate against measurement, compound 4: 1.8-fold (0.24 log units) below, and the stated range covers the measured number.
By their numbers in this assay, from the lowest: compound 1; then compounds 2 and 4 (each within the scatter of the next).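

In this assay, isopropyl in place of 4-methoxyphenyl on a saturated chain carbon bound to an amide-type nitrogen gives a 1.2-fold higher number from compound 2 to compound 4 (0.06 log units; within the scatter) and so stays within the scatter: at this place, the aromatic ring and its oxygen can be lost with no measurable change between these two compounds. The exchange of 4-methylpiperazin-1-yl for isobutylamino on a carbonyl carbon gives a 36-fold higher number from compound 1 to compound 4 (1.55 log units; beyond the scatter) and is of like size to a 31-fold higher number from compound 1 to compound 2 (1.49 log units; beyond the scatter) in this read-out, so the large gap to compound 1 appears with either of these two open-chain amide arms. Nothing measured here bears on why the numbers fall this way.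

The compounds shown leave open whether a dimethylamino group or a carboxylic acid at the end of the chain on the amide nitrogen would shift the number from that of compound 2. They also leave open whether morpholine, in place of 4-methylpiperazin-1-yl on the carbonyl carbon, would stay close to compound 1.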